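Replacing the 1-carboxyethyl group of compound 1

This account rests on a few compounds, and the source may have more. Where it says the series, first, only, none or still open, it means among the compounds named here.

Measured in a physicochemical assay for lipophilicity, read by HPLC, at pH 7.5; on this read-out higher numbers stand for higher lipophilicity and lower numbers for lower lipophilicity:
Compound 1 `CCOc1ccccc1-c1ccc(-c2nc3cnccc3c(NC(C)C(=O)O)c2C#N)cc1`: 2.1
Compound 2 `CC[C@@H](Nc1c(C#N)c(-c2ccc(-c3cccc(C)c3F)cc2)nc2cnccc12)C(N)=O`: 3
Compound 3 `CC[C@@H](Nc1c(C#N)c(-c2ccc(Br)cc2)nc2cnccc12)C(=O)O`: 1.6

Compound 1 is the second highest of these three, with compound 3 lower and compound 2 higher, both gaps beyond the scatter. Compound 4 `CCOc1ccccc1-c1ccc(-c2nc3cnccc3c(N[C@H](CC)C(=O)NS(C)(=O)=O)c2C#N)cc1` has not yet been measured in this assay. It keeps the core of compound 1 and changes in one place: a group of 10 heavy atoms (5 carbon, 1 nitrogen, 3 oxygen, 1 sulfur; no ring) in place of a group of 5 heavy atoms (3 carbon, 2 oxygen; no ring), on a nitrogen on an aromatic ring. Among the compounds with values here, no measured compound carries the entering group, so the data give only a thin guide. A modest rise beyond the scatter is expected in this assay. The estimated change is a number 0.50 log units higher from compound 1 to compound 4 (beyond the scatter). Compound 4 is expected at 2.6, with an estimated range from 2 to 3.2.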

Compound 4, distribution coefficient: 2.2
The estimate for compound 4 lay 0.40 log units above the measured number; low and high end bracket the measured number.
By their numbers in this assay, from the lowest: compound 3; then compounds 1 and 4 (each within the scatter of the next); then compound 2.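

At this position, on a nitrogen on an aromatic ring, a group of 10 heavy atoms replaces the 1-carboxyethyl group of 5 heavy atoms, and this assay gives a number 0.10 log units higher from compound 1 to compound 4 (within the scatter). Within the data shown here, this is the first single-place comparison here, and the larger group, with its sulfur and nitrogen, leaves the two compounds indistinguishable on this read-out. No measurement available here explains this result.

Still open, from the compounds shown here alone, is how an amine or a longer chain at this position would read on the core of compound 1.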